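Anilino for Phenyl on the Carbonyl of Compound 1

The source may hold more compounds than are shown below. What is called first, only, known or untested is meant among the compounds shown, and "the series" means these compounds.

Of the compounds shown here, two built on the same core have been measured in a functional assay on KB cells (Homo sapiens) for antiproliferative activity, read by MTT assay, with a stated time of 72 h; on this read-out lower numbers stand for stronger inhibition and higher numbers for weaker inhibition. Compound 1, `CN(C(=O)c1ccccc1)c1ccc2[nH]c(-c3n[nH]c4ccccc34)cc2n1`, gives 8580 nM in this assay. Compound 2, `CN(c1ccc2[nH]c(-c3n[nH]c4ccccc34)cc2n1)S(=O)(=O)c1cccc([N+](=O)[O-])c1`, gives 5870 nM in this assay. Compound 1 has the highest of the two numbers, yet its gap to compound 2 lies within the scatter of repeated measurements, so the two cannot be told apart on these figures and no ranking between them is claimed.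

Compound 3, `CN(C(=O)Nc1ccccc1)c1ccc2[nH]c(-c3n[nH]c4ccccc34)cc2n1`, has not yet been measured. It differs from compound 1 in one place: anilino in place of phenyl on a carbonyl carbon. Cut one bond further out, the same change reads as benzoyl becoming phenylcarbamoyl. For the measured compounds named here, no pair of measured compounds that differ in only one place is available, so no comparable step is known and the expectation rests on compound 1 alone.

The step of a 1.2-fold lower number from compound 1 to compound 3 (0.09 log units; within the scatter) is expected to be small, none beyond the usual scatter, in either direction. Compound 3 is therefore estimated to give 7000 nM in this assay, within a range from 2500 nM to 20000 nM.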

Compound 3, half-maximal inhibitory concentration: 32 nM
Estimate against measurement, compound 3: 220-fold (2.34 log units) above; the measured number lies below the stated range.
By their numbers in this assay, from the lowest: compound 3; then compounds 2 and 1 (each within the scatter of the next).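

In this assay, putting anilino in place of phenyl on a carbonyl carbon gives a 270-fold lower number from compound 1 to compound 3 (2.43 log units; beyond the scatter), which shows that this place on the molecule is highly sensitive to a change of only modest size. The group that leaves and the group that enters both carry a six-membered aromatic ring of carbon only, so the two compounds differ by the nitrogen of the anilino group and the hydrogen-bond donor counted there, and that small difference in structure goes with a very large difference in the read-out. Nothing available here explains the size of this step, so the result describes what happens and not why it happens.

The compounds shown leave open whether the step is tied to the hydrogen on the anilino nitrogen or to the presence of a linking atom between the carbonyl carbon and the ring, a question that a methylanilino or a phenoxy group on the same carbonyl carbon would address. They also leave open how far the ring itself can be changed, for example by a chlorine or a methoxy group on the phenyl ring of anilino.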